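The source may hold more compounds than are shown below. What is called first, only, known or untested is meant among the compounds shown, and "the series" means these compounds.

Measured so far in an ADME assay on microsomes from liver (Homo sapiens) for metabolic stability; on this read-out lower numbers stand for slow clearance and higher numbers for fast clearance:
Compound 1 `CC(C)n1cc(-c2ccnc3[nH]c(C4CCN(CC(=O)N(C)C)CC4)cc23)ccc1=O` gives < 3 uL/min, which is a limit of the assay rather than a number.
Compound 2 `CN(C)C(=O)CN1CCC(c2cc3c(-c4ccc(=O)n(CCC5CCOCC5)c4)ccnc3[nH]2)CC1` gives 19 uL/min.
Compound 3 `CN(C)C(=O)CN1CCC(c2cc3c(-c4ccc(=O)n(CC5CCOCC5)c4)ccnc3[nH]2)CC1` gives 20 uL/min.

Compound 3 stands with compound 2, as the step of a 1.1-fold higher number from compound 2 to compound 3 (0.02 log units; within the scatter) shows. The change to compound 4 `CN(C)C(=O)CN1CCC(c2cc3c(-c4ccc(=O)n(C5CCC5)c4)ccnc3[nH]2)CC1` is cyclobutyl in place of (oxan-4-yl)methyl on an aromatic nitrogen. Among the compounds with values here, the steps that bear on it run the other way: an at least 6.3-fold higher number from compound 1 to compound 2 (0.80 log units; beyond the scatter) and an at least 6.6-fold higher number from compound 1 to compound 3 (0.82 log units; beyond the scatter), both well beyond the scatter. Because an at least 6.6-fold higher number from compound 1 to compound 3 (0.82 log units; beyond the scatter) shows the larger oxanyl group going with the larger number, removing it in favour of a small carbon ring is expected to move compound 4 back toward compound 1, a drop of roughly a 3.3-fold lower number from compound 3 to compound 4 (0.52 log units; beyond the scatter). Compound 4 is therefore estimated at 6 uL/min, within 2 uL/min to 18 uL/min, with a fair chance that this assay reports only a limit.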

Compound 4, intrinsic clearance in a liver preparation (reported as CLH), per the amount of preparation that the assay uses: < 3 uL/min
Compound 4: only a limit was reported (the forecaster's own chance of this, stated with the estimate: 35%); at least 2.0-fold (0.30 log units) between middle value and limit.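

In this assay compound 4 gives < 3 uL/min, which is a limit of the assay and not a number. Cyclobutyl in place of (oxan-4-yl)methyl gives an at least 6.6-fold lower number from compound 3 to compound 4 (0.82 log units; beyond the scatter), and cyclobutyl in place of 2-(oxan-4-yl)ethyl gives an at least 6.3-fold lower number from compound 2 to compound 4 (0.80 log units; beyond the scatter), so at this aromatic nitrogen a ring of carbon only, like isopropyl, stands apart from both oxane-bearing groups. The step between compound 1 and compound 4 cannot be read, because both values are limits: the limit of < 3 uL/min in this assay, at which 2 of the 4 values shown sit. A cyclohexylmethyl group at this nitrogen would show whether the higher numbers go with the ring oxygen or with the larger group as a whole.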